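This account rests on a few compounds, and the source may have more. Where it says the series, first, only, none or still open, it means among the compounds named here.

Compound 2 `O=C(CSc1nnnn1-c1ccccc1)N/N=c1/scc(-c2ccc(F)cc2)n1-c1ccccc1` and compound 1 `Cc1ccc(-c2cs/c(=N/NC(=O)CSc3nnnn3-c3ccccc3)n2-c2ccccc2)cc1` share one core and differ only in a fluoro in place of a methyl on an aromatic carbon. In a functional assay on C6 cells (Rattus norvegicus) for cytotoxicity, read by MTT assay, with a stated time of 24 h, tested at 12 ug/mL (on this read-out higher numbers stand for a weaker effect at the one concentration tested and lower numbers for a stronger effect), compound 1 gives 55.1% and compound 2 gives 60%, so compound 2 holds the higher of the two numbers, though the gap a number 4.9 percentage points higher from compound 1 to compound 2 (within the scatter) lies within the scatter. Compound 3 `O=C(CSc1nnnn1-c1ccccc1)N/N=c1/scc(-c2ccc(Cl)cc2)n1-c1ccccc1` differs from compound 2 by chloro in place of fluoro on an aromatic carbon. For the measured compounds named here, the only comparable step is that small one, so no step beyond the scatter is expected from compound 2 to compound 3: the expected step is no change at the digits printed from compound 2 to compound 3 (within the scatter), and compound 3 is estimated at 60%, between 48% and 72%.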

Compound 3, a percentage reported as activity, at one concentration (the size of the read-out at that concentration, not a potency): 69.3%
For compound 3 the middle estimate is 9.3 percentage points below the measured one; measured number inside the range.
By their numbers in this assay, from the lowest: compounds 1, 2 and 3 (each within the scatter of the next, the first and the last beyond it).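

In this assay, chloro in place of fluoro on this aromatic carbon gives a number 9.3 percentage points higher from compound 2 to compound 3 (within the scatter), so swapping one halogen for the other shows no clear shift. Chloro in place of methyl, however, gives a number 14.2 percentage points higher from compound 1 to compound 3 (beyond the scatter), the first step at this position that clears the scatter, a modest move towards a weaker effect. The choice of group here can therefore matter, though only between these two groups so far.

Nothing available explains this step. Going by these compounds, how an amine or a carboxylic acid at this position would read remains open.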